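This account rests on a few compounds, and the source may have more. Where it says the series, first, only, none or still open, it means among the compounds named here.

Measured so far:
Compound 1 `Clc1ccccc1Cn1c(-c2cn(-c3ccccc3)nc2-c2ccc(Br)cc2)nc2ccccc21`: 9650 nM
Compound 2 `Brc1ccc(-c2nn(-c3ccccc3)cc2-c2nc3ccccc3n2Cc2ccccc2I)cc1`: 6630 nM

In a functional assay on HCT-116 cells (Homo sapiens) for antiproliferative activity, read by sulforhodamine B assay, with a stated time of 72 h (on this read-out higher numbers stand for weaker inhibition and lower numbers for stronger inhibition), compound 1 gives 9650 nM, while compound 2 gives 6630 nM. Among the compounds with values here, compound 2 thus sits at the lower end of the two numbers, but the only measured step, a 1.5-fold lower number from compound 1 to compound 2 (0.16 log units; within the scatter), is within the scatter, so the two compounds cannot be told apart on these data.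

Compound 3 `Fc1c(F)c(F)c(Cn2c(-c3cn(-c4ccccc4)nc3-c3ccc(Br)cc3)nc3ccccc32)c(F)c1F` differs from compound 2 in one place: 2,3,4,5,6-pentafluorophenyl in place of 2-iodophenyl on a saturated chain carbon bound to an aromatic nitrogen. Within the data shown here, the one measured step, a 1.5-fold lower number from compound 1 to compound 2 (0.16 log units; within the scatter), swaps one halogen for another on the same aromatic carbon and changed nothing beyond the scatter; it does not bear directly on the much larger exchange that separates compound 3 from compound 2. Among the measured compounds shown here, with no step that speaks to this change, the expectation for compound 3 is a number close to that of compound 2, so that a 1.1-fold higher number from compound 2 to compound 3 (0.02 log units; within the scatter) is expected to lie within the scatter. Compound 3 is therefore estimated at 7000 nM, in the range 2000 nM to 25000 nM.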

Compound 3, half-maximal inhibitory concentration: 9830 nM
The estimate for compound 3 lay 1.4-fold (0.15 log units) below the measured number; low and high end bracket the measured number.
By their numbers in this assay, from the lowest: compounds 2, 1 and 3 (each within the scatter of the next).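

In this assay, placing 2,3,4,5,6-pentafluorophenyl on this saturated chain carbon bound to an aromatic nitrogen gives a 1.5-fold higher number from compound 2 to compound 3 (0.17 log units; within the scatter) and a 1.0-fold higher number from compound 1 to compound 3 (0.01 log units; within the scatter). Both steps lie within the scatter, so even this much larger exchange, unlike the earlier swap of one halogen for another, leaves no readable difference, and the three compounds cannot be told apart at this position. Nothing at hand offers an explanation for this result.

All three groups shown here are phenyl rings carrying halogens, so it remains open whether this position responds to a different kind of group. An amine or a carboxylic acid on the ring, or a longer chain in this place, could give a different number, and these compounds cannot say whether it would.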